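Chain lengthening on two cores: working notes

A few compounds are considered here, and "the series" means these few. Any claim that something is new, unique, unknown or untested is made for them only; others in the source may bear on it.

Measured so far, in a functional assay on cells (Lymphocyte, Homo sapiens), read by a luciferase reporter and ATP content, with a stated time of 48 h, tested at 5 uM; on this read-out lower numbers stand for a stronger effect and higher numbers for a weaker effect at the one concentration tested:
compound 1, `CCCCCCCCCCCCCCc1nc(OC2CCC2)nc(N2CCC2)c1O`, gives 105%
compound 2, `CCCCCCCCCCCCCCCCc1nc(OC2CCC2)nc(N2CCC2)c1O`, gives 110%
compound 3, `CCCCCCCCCCCCCCc1nc(OC2CCC2)nc(OC2CCC2)c1O`, gives 98%

The change from compound 1 to compound 2 is ethyl in place of hydrogen on a saturated chain carbon, ten or more bonds along the chain from an aromatic carbon and it gave a number 5 percentage points higher from compound 1 to compound 2 (within the scatter). Compound 4, `CCCCCCCCCCCCCCCCc1nc(OC2CCC2)nc(OC2CCC2)c1O`, is not yet measured; it differs from compound 3 by ethyl in place of hydrogen on a saturated chain carbon, ten or more bonds along the chain from an aromatic carbon, the same change at the same place. The two cores differ by cyclobutyloxy in place of azetidin-1-yl on an aromatic carbon, and that difference gave a number 7 percentage points lower from compound 1 to compound 3 (within the scatter). Both known steps sit within the scatter, so no movement is established on either core.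

For compound 4 the step expected in this assay is a number 5 percentage points higher from compound 3 to compound 4 (within the scatter), resting on the earlier step of a number 5 percentage points higher from compound 1 to compound 2 (within the scatter) for compound 2, which was within the scatter. Compound 4 is therefore estimated at 103%, with the range 90% to 116%.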

Compound 4, a percentage reported as activity, at one concentration (the size of the read-out at that concentration, not a potency): 102%
Estimate against measurement, compound 4: 1 percentage points above; low and high end bracket the measured number.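

In this assay the chain change gives a number 4 percentage points higher from compound 3 to compound 4 (within the scatter), in line with the step on the other core: the same change on two cores in this assay, a number 5 percentage points higher (within the scatter) from compound 1 to compound 2 and a number 4 percentage points higher (within the scatter) from compound 3 to compound 4, 1 percentage points apart, within the scatter of two such steps. The core change, read with the longer chain, gives a number 8 percentage points lower from compound 2 to compound 4 (within the scatter), in line with the step read with the shorter chain: the same change on two cores in this assay, a number 7 percentage points lower (within the scatter) from compound 1 to compound 3 and a number 8 percentage points lower (within the scatter) from compound 2 to compound 4, 1 percentage points apart, within the scatter of two such steps. Going by these compounds alone, every one of these steps lies within the scatter, so the agreement shows only that neither change has an established effect on the cores compared, not that a real effect carries from one core to another.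

On these data alone, whether a step beyond the scatter would carry over in the same way stays open. So does the outcome with a much shorter chain, or with an amine or a carboxylic acid at the chain end.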